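The source may hold more compounds than are shown below. What is called first, only, known or untested is meant among the compounds shown, and "the series" means these compounds.

Among the compounds with values here, the series rests on a shared core carrying an aryl group on a sulfonyl sulfur, and the three measured members differ only in that aryl. In a functional assay on DLD-1 cells (Homo sapiens) for antiproliferative activity, read by CellTiter-Glo, with a stated time of 72 h (a higher number here means a weaker inhibitor, a lower number a stronger inhibitor), compound 1 `Cc1ccc(S(=O)(=O)N2CCC(N3CCC(C)CC3)CC2)cc1C` gives 24 nM, the lowest number of the three. Compound 2 `CC1CCN(C2CCN(S(=O)(=O)c3ccc(-c4ccccc4)cc3)CC2)CC1` gives 258 nM in this assay, and compound 3 `CC1CCN(C2CCN(S(=O)(=O)c3ccccc3-c3ccc(Cl)cc3)CC2)CC1` gives 202 nM; both stand beyond the scatter above compound 1. The untested compound 4 `CC1CCN(C2CCN(S(=O)(=O)c3ccc(Cl)c(Cl)c3)CC2)CC1` differs from compound 1 in one place: 3,4-dichlorophenyl in place of 3,4-dimethylphenyl on a sulfonyl sulfur. Within the data shown here, no measured pair shows this exact change, so its size in this assay is open; a small move toward a higher number, or none beyond the scatter, seems most likely. Compound 4 is therefore expected to give about 40 nM, with a range of 12 nM to 130 nM. That would mean an expected step of a 1.7-fold higher number from compound 1 to compound 4 (0.22 log units; within the scatter).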

Compound 4, half-maximal inhibitory concentration: 2.9 nM
For compound 4 the middle estimate is 14-fold (1.14 log units) above the measured one; measured number below the stated range.
By their numbers in this assay, from the lowest: compound 4; then compound 1; then compounds 3 and 2 (each within the scatter of the next).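

The aryl group on the sulfonyl sulfur responds strongly even to a change that leaves the heavy-atom count unaltered: in this assay, 3,4-dichlorophenyl in place of 3,4-dimethylphenyl gives an 8.3-fold lower number from compound 1 to compound 4 (0.92 log units; beyond the scatter), a step beyond the scatter. Neither group has hydrogen-bond donors or acceptors, so those counts do not separate them. Nothing available here explains the step. As far as these compounds go, it remains open whether a phenyl carrying one chlorine would retain this gain. From the compounds shown here alone, the effect of trifluoromethyl or nitrile groups in place of the chlorines is equally open.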